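A few compounds are considered here, and "the series" means these few. Any claim that something is new, unique, unknown or untested is made for them only; others in the source may bear on it.

Compound 1 `O=C(Nc1ccc(Oc2ccnc3[nH]ccc23)c(F)c1)c1nn(-c2ccc(Cl)c(C(F)(F)F)c2)ccc1=O` gives 11600 nM in a functional assay on MCF7 cells (Homo sapiens) for cytotoxicity, read by MTT assay, with a stated time of 72 h; on this read-out higher numbers stand for weaker inhibition and lower numbers for stronger inhibition.
Compound 2 `Cn1ccc2c(Oc3ccc(NC(=O)c4nn(-c5ccc(Br)cc5)ccc4=O)cc3F)ccnc21` gives 33600 nM in this assay.
Compound 3 `Cn1ccc2c(Oc3ccc(NC(=O)c4nn(-c5ccc(Br)cc5F)ccc4=O)cc3F)ccnc21` gives 14100 nM in this assay.

Among these three numbers compound 3 stands second highest; its nearest neighbour is compound 1, within the scatter, and its furthest is compound 2, beyond the scatter. Compound 4 `Cn1ccc2c(Oc3ccc(NC(=O)c4nn(-c5ccc(Cl)c(C(F)(F)F)c5)ccc4=O)cc3F)ccnc21` carries 4-chloro-3-(trifluoromethyl)phenyl in place of 4-bromo-2-fluorophenyl on an aromatic nitrogen. Among the measured compounds shown here, the one measured step, a 2.4-fold lower number from compound 2 to compound 3 (0.38 log units; beyond the scatter), concerns the fluoro that now leaves, so it bears only loosely here. Compound 1, which already carries the entering group on a closely related core, shows a number close to that of compound 3. The step of a 1.2-fold lower number from compound 3 to compound 4 (0.09 log units; within the scatter) is therefore expected to stay within the scatter. Compound 4 is estimated at 11500 nM, with a range from 5500 nM to 24000 nM.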

Compound 4, half-maximal inhibitory concentration: 18400 nM
Compound 4: the middle estimate sits 1.6-fold (0.20 log units) below what was measured; low and high end bracket the measured number.
By their numbers in this assay, from the lowest: compounds 1, 3, 4 and 2 (each within the scatter of the next, the first and the last beyond it).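

In this assay, exchanging the aryl group on the aromatic nitrogen stays within the scatter (a 1.3-fold higher number from compound 3 to compound 4 (0.12 log units; within the scatter)), and so does the exchange that starts from 4-bromophenyl (a 1.8-fold lower number from compound 2 to compound 4 (0.26 log units; within the scatter)). Methyl in place of hydrogen on the aromatic nitrogen of the core also stays within the scatter (a 1.6-fold higher number from compound 1 to compound 4 (0.20 log units; within the scatter)). Nothing given here offers an explanation for these numbers.

From the compounds shown here alone, whether an amine or a carboxylic acid on this aryl ring would give a step beyond the scatter stays open. Also open, going by these compounds, is how an ethyl group in place of the methyl on the core would read.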